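Swapping a benzyl group for an indole amide

The compounds below may be only part of what the source reports. "The series", "measured", "known", "first", "only" and "open" are said of these compounds alone.

In an assay on membranes from striatum (strain Sprague-Dawley) for displacement of a labelled ligand from sodium-dependent dopamine transporter (Rattus norvegicus), read by scintillation counting, with a stated time of 120 min (a lower number here means a stronger inhibitor, a higher number a weaker inhibitor), compound 2 `Fc1ccc(C(SCCNC2CCN(Cc3ccc(C(F)(F)F)cc3)CC2)c2ccc(F)cc2)cc1` gives 190 nM, the highest number of the three measured compounds; compound 1 `Fc1ccc(CN2CCC(NCCSC(c3ccc(F)cc3)c3ccc(F)cc3)CC2)cc1` gives 25.5 nM and compound 3 `[O-][S+](CCNC1CCN(Cc2ccc(F)cc2)CC1)C(c1ccc(F)cc1)c1ccc(F)cc1` gives 50.6 nM. Compound 4 `O=C(c1cc2ccccc2[nH]1)N1CCC(NCCSC(c2ccc(F)cc2)c2ccc(F)cc2)CC1` differs from compound 2 by (1H-indol-2-yl)carbonyl in place of 4-(trifluoromethyl)benzyl on an amine nitrogen in a ring. Going by the values given here, the only measured step, a 7.5-fold higher number from compound 1 to compound 2 (0.87 log units; beyond the scatter), concerns the trifluoromethyl that now leaves, so its removal might be expected to lower the number again; no measured step covers the change from a benzyl to a carbonyl on that ring nitrogen, which makes the outcome uncertain. The estimate for compound 4 in this assay is therefore a step of a 2.4-fold lower number from compound 2 to compound 4 (0.38 log units; beyond the scatter), expected as 80 nM with a range from 15 nM to 400 nM.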

Compound 4, inhibition constant: 177 nM
Beside the measured number, compound 4's estimate is 2.2-fold (0.34 log units) below it; the range from low to high includes it.
By their numbers in this assay, from the lowest: compounds 1 and 3 (each within the scatter of the next); then compounds 4 and 2 (each within the scatter of the next).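

In this assay, the ring nitrogen of the shared core tolerates (1H-indol-2-yl)carbonyl and 4-(trifluoromethyl)benzyl alike, with a 1.1-fold lower number from compound 2 to compound 4 (0.03 log units; within the scatter), so these two quite different groups cannot be told apart here. Set against 4-fluorobenzyl, the same amide gives a 6.9-fold higher number from compound 1 to compound 4 (0.84 log units; beyond the scatter), so it does not recover the number of compound 1. Nothing measured alongside these values explains why the two groups read alike. A plain benzoyl group would carry the carbonyl without the indole, and an (1H-indol-2-yl)methyl group the indole without the carbonyl. Going by these compounds, how each part contributes therefore stays open.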